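Trifluoromethyl added to the fluoro-bearing ring of compound 2

A few compounds are considered here, and "the series" means these few. Any claim that something is new, unique, unknown or untested is made for them only; others in the source may bear on it.

Compound 2 `Fc1ccccc1-c1ccc2[nH]c(C3=NOC4(CCCCC4)C3)nc2c1` gives 2.9 nM in a functional assay on HEK293 cells for antagonist activity at transient receptor potential M8 protein (Canis lupus familiaris), read by FLIPR and calcium flux; on this read-out lower numbers stand for stronger inhibition and higher numbers for weaker inhibition. Compound 1 `FC(F)(F)c1ccccc1-c1ccc2[nH]c(C3=NOC4(CCCCC4)C3)nc2c1` gives 3.1 nM in this assay, and the step from it to compound 2 is a 1.1-fold lower number from compound 1 to compound 2 (0.03 log units; within the scatter); the two numbers therefore stand together, and neither compound can be set apart from the other.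

Compound 3 `Fc1cccc(C(F)(F)F)c1-c1ccc2[nH]c(C3=NOC4(CCCCC4)C3)nc2c1` has not been measured. Compared with compound 2 it carries trifluoromethyl in place of hydrogen on an aromatic carbon, placed on an aromatic carbon of a six-membered aromatic ring of carbon only, ortho to a large group and meta to a fluoro group. Among the compounds with values here, the only measured step that bears on this position is the exchange of trifluoromethyl for fluoro from compound 1 to compound 2, which stayed within the scatter. Nothing here shows that a second substituent on that ring moves the number. Compound 3 is therefore expected to stay close to compound 2, with a step of a 1.4-fold higher number from compound 2 to compound 3 (0.14 log units; within the scatter), and its estimated value in this assay is 4 nM, within 1.5 nM to 12 nM.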

Compound 3, half-maximal inhibitory concentration: 0.6 nM
Beside the measured number, compound 3's estimate is 6.7-fold (0.82 log units) above it; measured number outside the range, below it.
By their numbers in this assay, from the lowest: compound 3; then compounds 2 and 1 (each within the scatter of the next).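

In this assay, trifluoromethyl on an aromatic carbon ortho to a large group and meta to a fluoro group gives a 4.8-fold lower number from compound 2 to compound 3 (0.68 log units; beyond the scatter), and fluoro in place of hydrogen gives a 5.2-fold lower number from compound 1 to compound 3 (0.71 log units; beyond the scatter). Within the data shown here, the earlier pair, with one of these groups each on that ring, could not be told apart, so this is the first sign that the ring's substitution can move the number beyond the scatter, and it appears only with both groups present. Nothing available bears on why the number falls with this change.

Whether both groups must be present in this arrangement remains open, as the shown compounds hold only this one doubly substituted ring. Also open, from the compounds shown here alone, is whether a nitrile or an amine on the same carbon would hold the lower number of compound 3.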